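Series notes: aryl exchange from compound 2 to compound 3

The source may report more compounds than this note shows. Statements on the series, on what has been measured and on what is new or still open speak of the compounds shown alone.

Of the compounds shown here, two with the shared core have numbers so far. Compound 1 `O=C(CSc1nc(Nc2ccccc2)c2ccccc2n1)Nc1ccc(F)c(Cl)c1` gives 9390 nM in a functional assay on NCI-H1975 cells (Homo sapiens) for inhibition, read by MTT assay, with a stated time of 72 h; a higher number here means a weaker inhibitor, a lower number a stronger inhibitor. Compound 2 `C=CC(=O)Nc1cccc(NC(=O)CSc2nc(Nc3ccccc3F)c3ccccc3n2)c1` gives 6580 nM in this assay; this is the lowest of the two numbers, but its gap to compound 1 lies within the scatter, so the two stand level on what is known. Among the compounds with values here, no step between measured compounds is available for a guide.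

Compound 3 `C=CC(=O)Nc1cccc(NC(=O)CSc2nc(Nc3cccc([N+](=O)[O-])c3)c3ccccc3n2)c1` is to be measured. It differs from compound 2 in one place: 3-nitrophenyl in place of 2-fluorophenyl on a nitrogen on an aromatic ring. Within the data shown here, with no measured step to go on, the expected step from compound 2 to compound 3 in this assay is a 1.0-fold lower number from compound 2 to compound 3 (0.01 log units; within the scatter), none beyond the scatter. Compound 3 is therefore expected to give about 6500 nM, estimated between 2000 nM and 20000 nM.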

Compound 3, half-maximal inhibitory concentration: 22600 nM
Compound 3: the middle estimate sits 3.5-fold (0.54 log units) below what was measured; the whole stated range lies below it.
By their numbers in this assay, from the lowest: compounds 2 and 1 (each within the scatter of the next); then compound 3.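

Within the data shown here, the aryl group on this nitrogen is the first place to give a step that can be read: in this assay the exchange of 2-fluorophenyl for 3-nitrophenyl gives a 3.4-fold higher number from compound 2 to compound 3 (0.54 log units; beyond the scatter) and so shows that this position is not indifferent to the aryl group it carries. The step is modest, and the exchange alters both the group on the ring and where it sits, as the two names show, so a single step cannot separate the two. Nothing available bears on the reason for the higher number.

Still open, on these data alone, is whether the nitro group itself or its place on the ring accounts for the step, and how an amine, a methoxy group or a carboxylic acid would read on the same phenyl ring. Also open, as far as these compounds go, is how the unsubstituted phenyl of compound 1 would read with the rest of compound 2, since these two compounds differ in more than one place.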